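Bromo in place of hydrogen on the phenyl of compound 1

This account rests on a few compounds, and the source may have more. Where it says the series, first, only, none or still open, it means among the compounds named here.

Compound 1 `COc1cc(/C=N/Nc2nc(-c3ccccc3)cs2)c(Br)c(Br)c1OC`: > 100000 nM
Compound 2 `COc1cc(/C=N/Nc2nc(-c3ccccc3)cs2)cc(Br)c1OC`: > 100000 nM

Going by the values given here, both compounds measured so far sit at the ceiling of an ADME assay on HUVEC cells (Homo sapiens) for inhibition, read by MTT assay, with a stated time of 48 h; a higher number here means a weaker inhibitor, a lower number a stronger inhibitor. In this assay compound 1 gives > 100000 nM, which is a limit of the assay and not a number. Compound 2 gives > 100000 nM in this assay, again a limit rather than a number. The step that the two limits leave unreadable from compound 1 to compound 2 stays unreadable because both of its ends rest at the limit of > 100000 nM in this assay, at which 2 of the 2 values shown sit. Compound 1 therefore stands only at a limit in this assay, with no measured number to anchor it.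

Compound 3 `COc1cc(/C=N/Nc2nc(-c3cccc(Br)c3)cs2)c(Br)c(Br)c1OC` has not yet been measured. Compared with compound 1 the change is bromo in place of hydrogen on an aromatic carbon. Among the compounds with values here, no measured step bears on a change of this kind, and the single recorded step is itself unreadable, so the data give no direction and no size for the move. With compound 1 at > 100000 nM, compound 3 is expected to remain near or at the limit, estimated at 150000 nM with a range of 40000 nM to 600000 nM. The step that the limit leaves unreadable from compound 1 to compound 3 is expected to stay within the scatter, with a high chance that only a limit is again reported.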

Compound 3, half-maximal inhibitory concentration: > 100000 nM
Compound 3: a limit, no number; the forecaster's own chance of this, stated with the estimate: 80%; the middle value lies beyond the limit too.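

In this assay compound 3 gives > 100000 nM, a limit and not a number. No step can be read between compound 1 and compound 3, since both ends rest at a limit: the limit of > 100000 nM in this assay, at which 3 of the 3 values shown sit.

The compounds shown leave open whether any change to the shared core gives a readable number in this assay.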